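Replacing the Bicyclic Tail of Compound 2

The source may hold more compounds than are shown below. What is called first, only, known or untested is meant among the compounds shown, and "the series" means these compounds.

Compound 2 `COc1ncccc1C(=O)NCCC1CCN(S(=O)(=O)NC(=O)NC[C@H]2C[C@@H]3CC[C@@H]2O3)CC1` holds the lower of the two measured numbers: in a functional assay on the whole organism (blood) with Rattus norvegicus as the target, with stated times of 24 h and 1 h, at a dose of 5 mg/kg by the intraperitoneal route (a higher number here means a stronger effect of the compound at the dose given, a lower number a weaker effect), compound 2 gives 14%, whereas compound 1 `COc1ccc(Cl)cc1C(=O)NCCC1CCN(S(=O)(=O)NC(=O)NC[C@H]2C[C@@H]3CC[C@@H]2O3)CC1` gives 27%, a step of a number 13 percentage points lower from compound 1 to compound 2 (beyond the scatter) made by swapping the group on the carbonyl carbon. Compound 3 `CCOCCNC(=O)NS(=O)(=O)N1CCC(CCNC(=O)c2cccnc2OC)CC1` differs from compound 2 elsewhere: a group of 4 heavy atoms (3 carbon, 1 oxygen; no ring) in place of a group of 7 heavy atoms (6 carbon, 1 oxygen; 2 five-membered non-aromatic rings with 1 hetero atom each), on a saturated chain carbon bound to an amide-type nitrogen. Going by the values given here, no measured step touches this saturated chain carbon bound to an amide-type nitrogen, so the direction is open, and a step of no more than the usual scatter is expected, no change at the digits printed from compound 2 to compound 3 (within the scatter). Compound 3 is thus estimated at 14%, with a range from 0% to 35%.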

Compound 3, a percentage reported as activity, at one dose (the size of the read-out at that dose, not a potency): 7%
Compound 3: middle estimate off by 7 percentage points, on the high side, within the range that was stated.
By their numbers in this assay, from the lowest: compounds 3 and 2 (each within the scatter of the next); then compound 1.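

Swapping the group with 2 five-membered non-aromatic rings for ethoxymethyl, on a saturated chain carbon bound to an amide-type nitrogen, gives a number 7 percentage points lower from compound 2 to compound 3 (within the scatter) in this assay. Going by these compounds alone, this is the first look at this position, and in this pair an open-chain group without defined stereocentres cannot be told apart from the ring-bearing one. Nothing available explains this result.

As far as these compounds go, whether the same swap would hold alongside the 5-chloro-2-methoxyphenyl group of compound 1 remains open. So does the outcome with an amine, a carboxylic acid or a longer chain at this carbon.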